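The source may report more compounds than this note shows. Statements on the series, on what has been measured and on what is new or still open speak of the compounds shown alone.

Working notes on the series, read in a toxicity assay on THP-1 cells (Homo sapiens) for inhibition; a lower number here means that less compound is tolerated, a higher number that more compound is tolerated. Compound 1 (`Cn1c(-c2ccccc2)cnc1NC(=O)c1ccc(F)cc1`) gives only a limit (> 100000 nM). Compound 2 (`COc1ccc(-c2cnc(NC(=O)c3ccccc3O)n2C)cc1`) likewise gives only a limit (> 100000 nM). Compound 3 (`Cc1ccccc1C(=O)Nc1ncc(-c2ccccc2)n1C`) also stands only at a limit (> 100000 nM), so no number fixes its place in the series. Across these compounds the record is the limit of > 100000 nM in this assay, at which 3 of the 3 values shown sit, and nothing finer.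

Compound 4 (`Cc1cccc(C(=O)Nc2ncc(-c3ccccc3)n2C)c1`) differs from compound 3 as follows: 3-methylphenyl in place of 2-methylphenyl on a carbonyl carbon.

Within the data shown here, the one measured step at this carbonyl carbon is a step that the two limits leave unreadable from compound 1 to compound 3 and it offers no size to carry over. No clear step is expected for compound 4 because compound 3 gives only the limit > 100000 nM and no measured change in the series has moved off it. The estimated move is a number no higher from compound 3 to compound 4 (the limit leaves the size open) and no direction is expected for it. For compound 4 the estimate is 100000 nM (expected range 50000 nM to 100000 nM), and a further report as a limit is the likeliest outcome.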

Compound 4, half-maximal cytotoxic concentration: > 50000 nM
Compound 4: no number, only a limit (the forecaster's own chance of this, stated with the estimate: 85%); the middle value lies beyond the limit too.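

Compound 4 gives only a limit, > 50000 nM, and not a number. Neither the step from compound 3 to compound 4 nor the step from compound 1 to compound 4 can be read. The compounds shown leave open whether 4-fluorophenyl, 2-methylphenyl and 3-methylphenyl on the carbonyl carbon differ at all in how much compound is tolerated.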